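The compounds below may be only part of what the source reports. "The series", "measured", "known", "first", "only" and "open" are said of these compounds alone.

Measured compounds:
compound 1, `CC(C)c1noc(N2CCC(Oc3cc(N4CCc5cc(C6CCCCC6=O)ccc54)ncn3)CC2)n1`, 48 nM in an assay on CHO cells for agonist activity at Glucose-dependent insulinotropic receptor (Homo sapiens), read by a luciferase reporter and cAMP accumulation, with a stated time of 2 h; on this read-out lower numbers stand for an effect already at smaller amounts and higher numbers for an effect only at larger amounts of compound
compound 2, `CC(C)c1noc(N2CCC(Oc3cc(N4CCc5cc(N6CCCS6(=O)=O)ccc54)ncn3)CC2)n1`, 9.7 nM
compound 3, `CC(=O)N(C)c1ccc2c(c1)CCN2c1cc(OC2CCN(c3nc(C(C)C)no3)CC2)ncn1`, 75 nM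

Compound 3 shows the highest of the three numbers in this assay. Its gap to compound 1 is small: the step of a 1.6-fold higher number from compound 1 to compound 3 (0.19 log units; within the scatter) stays within the usual scatter of repeated measurements. Its gap to compound 2 is larger: the step of a 7.7-fold higher number from compound 2 to compound 3 (0.89 log units; beyond the scatter) lies beyond the scatter, and it is compound 2, carrying the five-membered non-aromatic ring with two hetero atoms, that gives the lowest number of the set.

Compound 4, `CC(C)c1noc(N2CCC(Oc3cc(N4CCc5cc(S(=O)(=O)CCO)ccc54)ncn3)CC2)n1`, has not yet been measured. It differs from compound 3 in one place: (2-hydroxyethyl)sulfonyl in place of acetyl(methyl)amino on an aromatic carbon. Among the measured compounds shown here, two measured steps bear on this change. The step of a 4.9-fold lower number from compound 1 to compound 2 (0.69 log units; beyond the scatter) brought in a sulfur-bearing ring in place of 2-oxocyclohexyl and gave a lower number, and the step of a 7.7-fold higher number from compound 2 to compound 3 (0.89 log units; beyond the scatter) removed that sulfur-bearing ring in favour of acetyl(methyl)amino and gave a higher number. Compound 4 again carries sulfur with two oxygens on the same aromatic carbon, though as an open chain rather than in a ring, so a step of similar direction but uncertain size is expected: a 3.4-fold lower number from compound 3 to compound 4 (0.53 log units; beyond the scatter). For compound 4 the expected value is 22 nM, with a range from 8 nM to 65 nM.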

Compound 4, half-maximal effective concentration: 41 nM
The estimate for compound 4 lay 1.9-fold (0.27 log units) below the measured number; the measured number falls inside the stated range.
By their numbers in this assay, from the lowest: compound 2; then compounds 4, 1 and 3 (each within the scatter of the next).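

In this assay, sulfur bearing two oxygens on this aromatic carbon does not by itself give the low number seen for compound 2: with the open-chain (2-hydroxyethyl)sulfonyl group, the change is a 4.2-fold higher number from compound 2 to compound 4 (0.63 log units; beyond the scatter), a real loss against the five-membered ring. The new group also cannot be told apart from the two groups without sulfur, as both a 1.8-fold lower number from compound 3 to compound 4 (0.26 log units; within the scatter) and a 1.2-fold lower number from compound 1 to compound 4 (0.07 log units; within the scatter) stay within the scatter, so at this position an acetyl(methyl)amino group, a 2-oxocyclohexyl group and this sulfonyl chain all perform alike, and only the ring of compound 2 stands out. Nothing measured here explains why the ring and the open chain differ.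

The compounds shown leave open whether the gap to compound 2 goes with the closed ring, with the nitrogen that attaches that ring to the aromatic carbon, or with the hydroxyl group at the end of the chain. A methylsulfonyl group, which has no hydroxyl group, and an open-chain sulfonamide on the same aromatic carbon would help to separate these possibilities.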